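A Neutral Amine in Place of a Charged Sulfur Group

The source may hold more compounds than are shown below. What is called first, only, known or untested is meant among the compounds shown, and "the series" means these compounds.

Of the compounds shown here, three built on one shared core have been measured in a functional assay (brain) for inhibition, with Rattus norvegicus as the target; on this read-out lower numbers stand for stronger inhibition and higher numbers for weaker inhibition. Compound 1 `Cc1c(C)c2c(c(C)c1O)CC[C@@](C)(CC[N+](C)(C)C)O2` gives 2300 nM. Compound 2 `Cc1c(C)c2c(c(C)c1O)CC[C@](C)(CC[S+](C)C)O2` gives 2000 nM, and compound 3 `Cc1c(C)c2c(c(C)c1O)CC[C@@](C)(CC[S+](C)C)O2` gives 2000 nM. Compound 2 thus stands level with compound 3 at the digits shown, the two sharing the lowest number of the three, while compound 1 is the one furthest from compound 2, and even that gap lies within the scatter. The first measured step runs a 1.2-fold lower number from compound 1 to compound 3 (0.06 log units; within the scatter). The second runs no change at the digits printed from compound 2 to compound 3 (within the scatter), and this outcome rests on (the fact that compounds 2 and 3 differ only in the configuration as drawn).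

Compound 4 `Cc1c(C)c2c(c(C)c1O)CC[C@](C)(CCN(C)C)O2` has not been measured. It differs from compound 2 in one place: a group of 3 heavy atoms (2 carbon, 1 nitrogen; no ring) in place of a group of 3 heavy atoms (2 carbon, 1 sulfur; no ring), on a saturated chain carbon, two bonds along the chain from a saturated ring carbon. Neither measured step matches this kind of change. For the measured compounds named here, the first exchanged one charged group for another charged group, and the second only altered the configuration as drawn, so no measured step shows what replacing a charged group by an uncharged one does here. With both measured steps within the scatter, the expectation for compound 4 is a step of no clear direction, and the expected step is a 1.1-fold lower number from compound 2 to compound 4 (0.05 log units; within the scatter). Compound 4 is therefore estimated to give 1800 nM, within a range from 500 nM to 6000 nM.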

Compound 4, half-maximal inhibitory concentration: 1000 nM
For compound 4 the middle estimate is 1.8-fold (0.26 log units) above the measured one; low and high end bracket the measured number.
By their numbers in this assay, from the lowest: compounds 4, 2, 3 and 1 (each within the scatter of the next, the first and the last beyond it).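

For the compounds shown here, this is the first step that removes a net charge: a group with net charge +1 leaves and dimethylamino, with no net charge, enters on a saturated chain carbon, two bonds along the chain from a saturated ring carbon. In this assay this exchange gives a 2.0-fold lower number from compound 2 to compound 4 (0.30 log units; within the scatter) and so shows that, in this comparison, the net charge on this group is not needed to keep the number within the scatter of the charged sulfur compound. Going by these compounds alone, nothing given here accounts for the size of this step, and the one available note on compounds 2 and 3 concerns configuration rather than this exchange.

Going by these compounds, it remains open whether dimethylamino would behave the same way with the opposite configuration at the saturated ring carbon, where the charged sulfur pair of compound 2 and compound 3 shows no change. Also open, on these data alone, is how the number would respond to other groups at this place, such as a carboxylic acid, a primary amine or a longer chain carrying the dimethylamino group.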